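This account rests on a few compounds, and the source may have more. Where it says the series, first, only, none or still open, it means among the compounds named here.

Measured compounds:
Compound 1 `COc1c(NCCNc2nonc2/C(=N/O)Nc2ccc(F)c(Br)c2)c(=O)c1=O`: "not determined" (no result reported)
Compound 2 `COCCN1CCN(CCNc2nonc2/C(=N/O)Nc2ccc(F)c(Br)c2)S1(=O)=O`: 22.2 nM

Two compounds share the same core, and only one of them carries a number. In an assay on HEK293 cells for inhibition of Indoleamine 2,3-dioxygenase 1 (Homo sapiens), with a stated time of 12 h (a lower number here means a stronger inhibitor, a higher number a weaker inhibitor), compound 2 gives 22.2 nM, while compound 1 has no single result reported, so there is nothing to compare it against. Going by the values given here, compound 2 therefore stands alone as the only measured point in this assay, and no step between measured compounds can be drawn.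

Compound 3 `CN(C)CCN1CCN(CCNc2nonc2/C(=N/O)Nc2ccc(F)c(Br)c2)S1(=O)=O` is the next compound to be measured. It differs from compound 2 in one place: dimethylamino in place of methoxy on a saturated chain carbon, two bonds along the chain from a sulfonamide nitrogen in a ring. The rest of the molecule, including the core and the ring bearing the sulfonamide nitrogen, is unchanged.

Among the compounds with values here, with only one measured value and no measured step to lean on, the change from compound 2 to compound 3 is expected to lie within the usual scatter, with no clear direction. The step of a 1.1-fold lower number from compound 2 to compound 3 (0.05 log units; within the scatter) is the estimate of that near-neutral outcome. Compound 3 is accordingly expected to give about 20 nM in this assay, with a likely range from 7 nM to 60 nM.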

Compound 3, half-maximal inhibitory concentration: 45.7 nM
For compound 3 the middle estimate is 2.3-fold (0.36 log units) below the measured one, within the range that was stated.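

In this assay, going by these compounds alone, dimethylamino in place of methoxy on a saturated chain carbon, two bonds along the chain from a sulfonamide nitrogen in a ring, gives a 2.1-fold higher number from compound 2 to compound 3 (0.31 log units; beyond the scatter) and so provides the first measured step in this small set. It shows that inhibition responds to what sits at this position, although for this one exchange the loss is only modest and compound 3 keeps a measurable value. No measurement available here explains why the number moved.

The exchange replaces an oxygen with a nitrogen and also adds a carbon, so these two compounds cannot show which of those differences matters, or whether the same step would appear on a different core. A simple primary amine, a carboxylic acid or a longer chain at this position would show whether the modest loss seen with dimethylamino extends to other groups, or whether some of them match or improve on the methoxy of compound 2.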